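The compounds below may be only part of what the source reports. "The series", "measured", "known", "first", "only" and "open" are said of these compounds alone.

Compound 3 `COc1ccccc1C1CCN(c2ccn(CC3CC3)c(=O)c2C#N)CC1` stands lowest of the three numbers in a functional assay on CHO cells for positive allosteric modulation of metabotropic glutamate receptor 2 (Homo sapiens), with a stated time of 30 min; a higher number here means that more compound is needed for the effect, a lower number that less compound is needed: compound 3 gives 35 nM, while compound 1 `N#Cc1c(N2CCC(c3ccccc3F)CC2)ccn(CC2CC2)c1=O` gives 81 nM and compound 2 `N#Cc1c(N2CCC(c3cccc(F)c3)CC2)ccn(CC2CC2)c1=O` gives 141 nM. Both steps into compound 3 lie beyond the scatter, a 2.3-fold lower number from compound 1 to compound 3 (0.36 log units; beyond the scatter) and a 4.0-fold lower number from compound 2 to compound 3 (0.61 log units; beyond the scatter), the second one being the larger. Compound 4 `COc1ccc(C2CCN(c3ccn(CC4CC4)c(=O)c3C#N)CC2)cc1` differs from compound 3 by 4-methoxyphenyl in place of 2-methoxyphenyl on a saturated ring carbon, so the same atoms are kept and only the methoxy is moved around the phenyl ring. For the measured compounds named here, no measured pair moves a methoxy group; the only precedent for moving a substituent on this phenyl ring is a 1.7-fold higher number from compound 1 to compound 2 (0.24 log units; within the scatter), a change from 2-fluorophenyl to 3-fluorophenyl that stayed within the scatter. That step says nothing about 4-methoxyphenyl, and the data give no reason to expect a gain beyond compound 3. A small rise in the number, possibly within the scatter, is the working expectation. Compound 4 is therefore estimated at 60 nM, with a range of 25 nM to 150 nM, which means an expected step of a 1.7-fold higher number from compound 3 to compound 4 (0.23 log units; within the scatter).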

Compound 4, half-maximal effective concentration: 98 nM
Estimate against measurement, compound 4: 1.6-fold (0.21 log units) below, within the range that was stated.
By their numbers in this assay, from the lowest: compound 3; then compounds 1, 4 and 2 (each within the scatter of the next).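

Moving the methoxy from 2-methoxyphenyl to 4-methoxyphenyl gives the first measured shift of this group around the phenyl ring, and in this assay the shift is readable (a 2.8-fold higher number from compound 3 to compound 4 (0.45 log units; beyond the scatter)). The place of a substituent on this phenyl ring can therefore matter for the methoxy group, which the fluoro pair, with its step within the scatter, did not show. Compound 4 is not separated from the fluoro compounds (a 1.4-fold lower number from compound 2 to compound 4 (0.16 log units; within the scatter); a 1.2-fold higher number from compound 1 to compound 4 (0.08 log units; within the scatter)), so a methoxy group alone does not set compound 3 apart, and nothing at hand bears on why the place matters.

Still open, as far as these compounds go, is whether the low number of compound 3 survives an ethoxy group in place of the methoxy of 2-methoxyphenyl. Also open, from the compounds shown here alone, is how an amine or a carboxylic acid on the same ring would read.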